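A few compounds are considered here, and "the series" means these few. Any claim that something is new, unique, unknown or untested is made for them only; others in the source may bear on it.

Compound 1 `Cc1nc(N)sc1CCCN/C(N)=N/C(=O)NC(C)c1ccccc1F` is examined in a functional assay on Right cardiac atrium for agonist activity at histamine H2 receptor (Cavia porcellus), with a stated time of 30 min, in the presence of a further agent that is not named here (on this read-out lower numbers stand for an effect already at smaller amounts and higher numbers for an effect only at larger amounts of compound), where compound 1 gives 12.3 nM. Of the three values measured this is the second highest: compound 2 `CCC(NC(=O)/N=C(\N)NCCCc1sc(N)nc1C)c1ccccc1` gives 10.7 nM, which lies within the scatter of compound 1, whereas compound 3 `Cc1nc(N)sc1CCCN/C(N)=N/C(=S)NC(c1ccccc1)c1ccccc1` gives 66.1 nM, a gap beyond the scatter. Compound 4 `Cc1nc(N)sc1CCCN/C(N)=N/C(=O)NC(C)c1ccco1` has not yet been measured; it carries furan-2-yl in place of 2-fluorophenyl on a saturated chain carbon bound to an amide-type nitrogen and a saturated chain carbon on the shared core. Going by the values given here, no measured pair isolates a change of the aromatic group, so the direction is uncertain. Compound 4 is expected to show a 1.6-fold higher number from compound 1 to compound 4 (0.21 log units; within the scatter), a step that may well stay within the scatter, with a slight lean toward higher numbers. Compound 4 is therefore estimated at 20 nM, with a range from 7 nM to 60 nM.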

Compound 4, half-maximal effective concentration: 9.77 nM
Compound 4: the middle estimate sits 2.0-fold (0.31 log units) above what was measured; the range from low to high includes it.
By their numbers in this assay, from the lowest: compounds 4, 2 and 1 (each within the scatter of the next); then compound 3.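

Going by these compounds alone, the first step that isolates the aromatic group on this saturated chain carbon, bound to an amide-type nitrogen and a saturated chain carbon, is a 1.3-fold lower number from compound 1 to compound 4 (0.10 log units; within the scatter) when furan-2-yl replaces 2-fluorophenyl. At this position, then, a five-membered aromatic ring with 1 hetero atom and a fluorinated six-membered carbon ring cannot be told apart on this read-out. Nothing measured here explains this result. On these data alone, whether an amine or a carboxylic acid in place of the aromatic group would leave the number within the scatter remains open.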